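Epimer step on the benzimidazole-acetyl thiosemicarbazide glycosides

A few compounds are considered here, and "the series" means these few. Any claim that something is new, unique, unknown or untested is made for them only; others in the source may bear on it.

Compound 3, `COc1ccc(C(=O)Nc2nc3ccccc3n2CC(=O)NNC(=S)N[C@@H]2O[C@H](CO)[C@@H](O)[C@H](OC(C)=O)[C@H]2OC(C)=O)cc1`, is the reference for this note. In a functional assay on PG cells (Homo sapiens) for cytotoxicity, read by MTT assay, with a stated time of 48 h (a lower number here means that less compound is needed, a higher number that more compound is needed for the effect), compound 3 gives 54900 nM, the lowest of the two plain numbers in the set, with compound 1 nearest at a step of a 1.5-fold lower number from compound 1 to compound 3 (0.18 log units; within the scatter). Compound 1, `CC(=O)O[C@@H]1[C@@H](OC(C)=O)[C@H](O)[C@@H](CO)O[C@H]1NC(=S)NNC(=O)Cn1cnc2ccccc21`, gives 82200 nM in this assay. Compound 2, `CC(=O)O[C@@H]1[C@@H](OC(C)=O)[C@@H](O)[C@@H](CO)O[C@H]1NC(=S)NNC(=O)Cn1cnc2ccccc21`, is reported in this assay only as a limit of > 100000 nM.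

Compound 4, `COc1ccc(C(=O)Nc2nc3ccccc3n2CC(=O)NNC(=S)N[C@@H]2O[C@H](CO)[C@H](O)[C@H](OC(C)=O)[C@H]2OC(C)=O)cc1`, is the unmeasured partner of compound 3. The change is the two compounds have the same atoms and bonds and differ only in configuration as drawn: 1 of 5 stereo elements differ; a stereocentre at a saturated ring carbon is drawn R in compound 3 and S in compound 4.

Within the data shown here, the one measured step of the same kind is that from compound 1 to compound 2, an at least 1.2-fold higher number from compound 1 to compound 2 (0.08 log units; that floor lies within the scatter), whose size cannot be fixed because the limit of > 100000 nM in this assay, at which 1 of the 3 values shown sits, leaves only a floor; what is clear is that the change of configuration, (the fact that compounds 1 and 2 differ only in the configuration as drawn), did not lower the number. The same direction is therefore expected here, with a floor of the same order, and a fair chance that compound 4 also ends at the limit of this assay.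

For compound 4 a step of a 1.7-fold higher number from compound 3 to compound 4 (0.24 log units; within the scatter) is expected. The estimate for compound 4 in this assay is 95000 nM, with a range from 55000 nM to 200000 nM.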

Compound 4, half-maximal effective concentration: 82400 nM
Compound 4: middle estimate off by 1.2-fold (0.06 log units), on the high side; the range from low to high includes it.
By their numbers in this assay, from the lowest: compounds 3, 1 and 4 (each within the scatter of the next). At a limit, above all of these: compound 2.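

In this assay the change of configuration at this saturated ring carbon now has a plain number on both sides, a 1.5-fold higher number from compound 3 to compound 4 (0.18 log units; within the scatter), and on the core bearing ((4-methoxyphenyl)carbonyl)amino this inversion does not separate the two epimers beyond the scatter: the fact that compounds 3 and 4 differ only in the configuration as drawn

The ((4-methoxyphenyl)carbonyl)amino change can now also be followed on the second configuration, an at least 1.2-fold lower number from compound 2 to compound 4 (0.08 log units; that floor lies within the scatter), though this step gives only a floor and does not show a difference beyond the scatter.

Compound 2 remains a limit in this assay, at > 100000 nM.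

Whether the inversion has the same size on the core of compound 1 as on the substituted core cannot be read, and neither can any gap between the two ((4-methoxyphenyl)carbonyl)amino steps, as long as compound 2 is known only as a limit. Also open, as far as these compounds go, is how this assay responds to an amine or a carboxylic acid in place of the ((4-methoxyphenyl)carbonyl)amino group, and whether either group would give a step beyond the scatter on one or both configurations.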